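A few compounds are considered here, and "the series" means these few. Any claim that something is new, unique, unknown or untested is made for them only; others in the source may bear on it.

Measured compounds and their values in a functional assay on HL-60 cells (Homo sapiens) for inhibition, read by MTT assay, with a stated time of 72 h; on this read-out higher numbers stand for weaker inhibition and lower numbers for stronger inhibition:

Compound 1, `Cc1nc(-c2ccccc2)c(C(=O)N2CCN(c3cccc(Cl)c3)CC2)o1`: 39.2 nM
Compound 2, `Cc1ccc(N2CCN(C(=O)c3oc(C)nc3-c3ccccc3)CC2)c(C)c1`: 101 nM

Of the two numbers, compound 1 holds the lower one. Within the data shown here, the single measured step, a 2.6-fold higher number from compound 1 to compound 2 (0.41 log units; beyond the scatter), came with 2,4-dimethylphenyl in place of 3-chlorophenyl on an amine nitrogen in a ring, and so it concerns the far end of the shared core.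

Compound 3, `Cc1nc(-c2ccccc2F)c(C(=O)N2CCN(c3cccc(Cl)c3)CC2)o1`, keeps the 3-chlorophenyl of compound 1 and differs from it at the other end: fluoro in place of hydrogen on an aromatic carbon The change sits on an aromatic carbon of a six-membered aromatic ring of carbon only, ortho to a large group; cut one bond further out it reads phenyl to 2-fluorophenyl.

Among the measured compounds shown here, no measured step touches this position, so there is nothing in these two compounds from which a direction could be read. For the measured compounds named here, the only guide is that the fluoro enters as a single heavy atom with no ring, no donors and no acceptors. Compound 3 is therefore expected to show a step of about a 1.0-fold higher number from compound 1 to compound 3 (0.01 log units; within the scatter), which is not beyond the scatter. Compound 3 is estimated at 40 nM, with a range from 15 nM to 110 nM.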

Compound 3, half-maximal inhibitory concentration: 39.4 nM
Beside the measured number, compound 3's estimate is 1.0-fold (0.01 log units) above it; the measured number falls inside the stated range.
By their numbers in this assay, from the lowest: compounds 1 and 3 (each within the scatter of the next); then compound 2.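

In this assay, fluoro in place of hydrogen on an aromatic carbon, ortho to a large group, gives a 1.0-fold higher number from compound 1 to compound 3 (0.00 log units; within the scatter), so compound 1 and compound 3 cannot be told apart on this read-out. Among these compounds, this is the first reading at the phenyl end of the shared core, and it shows that, with the 3-chlorophenyl kept, this position takes the phenyl to 2-fluorophenyl change without a step beyond the scatter, whereas the one earlier step, a 2.6-fold higher number from compound 1 to compound 2 (0.41 log units; beyond the scatter), at the far end of the core, does lie beyond it. No evidence on the reason for this result is available.

The compounds shown leave open whether a larger group at this same place, such as a methoxy group, a chloro or an amine, would also stay within the scatter, and whether fluoro on other aromatic carbons of this ring would read the same way. They also leave open whether the 2-fluorophenyl would give a similar reading when paired with the 2,4-dimethylphenyl of compound 2.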